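A few compounds are considered here, and "the series" means these few. Any claim that something is new, unique, unknown or untested is made for them only; others in the source may bear on it.

Working notes on the series.

All three measured compounds share one core, carrying a sulfonyl-linked aromatic ring. Among the measured compounds shown here, in a functional assay on DLD-1 cells (Homo sapiens) for antiproliferative activity, read by CellTiter-Glo, with a stated time of 72 h (on this read-out lower numbers stand for stronger inhibition and higher numbers for weaker inhibition), compound 3 `CC1CCN(C2CCN(S(=O)(=O)c3cccc(-c4ccccc4C(F)(F)F)c3)CC2)CC1` gives 10 nM, the lowest of the three numbers so far. Compound 1 `COc1ccccc1-c1cccc(S(=O)(=O)N2CCC(N3CCC(C)CC3)CC2)c1` gives 21 nM and compound 2 `Cc1cccc(S(=O)(=O)N2CCC(N3CCC(C)CC3)CC2)c1` gives 25 nM. The step of a 2.1-fold lower number from compound 1 to compound 3 (0.32 log units; beyond the scatter) is modest, as is a 2.5-fold lower number from compound 2 to compound 3 (0.40 log units; beyond the scatter), while a 1.2-fold higher number from compound 1 to compound 2 (0.08 log units; within the scatter) stays within the scatter.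

Compound 4 `CC1CCN(C2CCN(S(=O)(=O)c3cccc(Br)c3)CC2)CC1` has not yet been measured. It differs from compound 3 in one place: bromo in place of 2-(trifluoromethyl)phenyl on an aromatic carbon. The step that bears on this is a 2.5-fold lower number from compound 2 to compound 3 (0.40 log units; beyond the scatter), since compound 2, like compound 4, carries a single substituent without a ring at that carbon instead of the trifluoromethyl-bearing phenyl; read in reverse it points to a modest loss. Nothing measured separates bromo from methyl at this position, so the bromo analogue is taken to sit near compound 2. The expected step is a 2.5-fold higher number from compound 3 to compound 4 (0.40 log units; beyond the scatter), a modest rise. Compound 4 is therefore expected to give about 25 nM, within 10 nM to 60 nM.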

Compound 4, half-maximal inhibitory concentration: 3.2 nM
The estimate for compound 4 lay 7.8-fold (0.89 log units) above the measured number, and the stated range ends above it.
By their numbers in this assay, from the lowest: compound 4; then compound 3; then compounds 1 and 2 (each within the scatter of the next).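

At this aromatic carbon, bromo gives a 3.1-fold lower number from compound 3 to compound 4 (0.49 log units; beyond the scatter) in this assay, so the 2-(trifluoromethyl)phenyl ring is not required for the low numbers in this series. The earlier compounds gave a ring-free substituent only as methyl, whereas bromo in place of methyl gives a 7.8-fold lower number from compound 2 to compound 4 (0.89 log units; beyond the scatter) and bromo in place of 2-methoxyphenyl gives a 6.6-fold lower number from compound 1 to compound 4 (0.82 log units; beyond the scatter), so among these compounds the presence of a ring does not set the order: methyl stands above the 2-(trifluoromethyl)phenyl compound and bromo below it. No measurement on hand accounts for the difference between bromo and methyl at this carbon.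

The compounds shown leave open whether chloro, iodo or a nitrile at this carbon would track bromo or methyl. They also leave open how an amine or a carboxylic acid would read out there, and whether bromo at another ring carbon would give a similar number.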